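The compounds below may be only part of what the source reports. "The series", "measured", "known", "first", "only" and "open" are said of these compounds alone.

Measured in an ADME assay on cells (Hepatocyte, Mus musculus) for metabolic stability, with a stated time of 30 min (a higher number here means that more of the compound is left, a lower number that less of the compound is left), so far:
- compound 1 `O=C(OC1CCC(CN2CCN(c3cc(=O)c4cc(C(F)(F)F)cc([N+](=O)[O-])c4s3)CC2)CC1)c1ccncc1` gives 1.4%
- compound 2 `Cc1ccc(C(=O)OC2CCC(CN3CCN(c4cc(=O)c5cc(C(F)(F)F)cc([N+](=O)[O-])c5s4)CC3)CC2)cc1` gives 18%
- compound 3 `O=c1cc(N2CCN(CC3CCCCC3)CC2)sc2c([N+](=O)[O-])cc(C(F)(F)F)cc12` gives 80.6%

Compound 3 stands highest of the three, well clear of both others. Compound 4 `O=C(OC1CCC(CN2CCN(c3cc(=O)c4cc(C(F)(F)F)cc([N+](=O)[O-])c4s3)CC2)CC1)c1cccs1` has not yet been measured in this assay and differs from compound 3 in one place: ((thiophen-2-yl)carbonyl)oxy in place of hydrogen on a saturated ring carbon. In words, ((thiophen-2-yl)carbonyl)oxy takes the place of hydrogen on a saturated ring carbon.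

Among the compounds with values here, two measured steps bear directly on this change, and both are large: a number 79.2 percentage points higher from compound 1 to compound 3 (beyond the scatter) and a number 62.6 percentage points higher from compound 2 to compound 3 (beyond the scatter). Each removes a comparable group from that same carbon, ((pyridin-4-yl)carbonyl)oxy in compound 1 and ((4-methylphenyl)carbonyl)oxy in compound 2. Adding such a group back is therefore expected to work in the opposite direction. The third step, a number 16.6 percentage points higher from compound 1 to compound 2 (beyond the scatter), is modest but beyond the scatter, so the ring carried by the carbonyl also counts. Within the data shown here, no compound with a thiophene ring has been measured, which leaves the exact landing point open.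

A large fall is expected, estimated as a number 70.6 percentage points lower from compound 3 to compound 4 (beyond the scatter) and still unconfirmed. For compound 4 the estimated value is 10%, with an expected range from 1% to 30%.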

Compound 4, percent of the compound remaining: 1.8%
For compound 4 the middle estimate is 8.2 percentage points above the measured one; the range from low to high includes it.
By their numbers in this assay, from the lowest: compounds 1 and 4 (each within the scatter of the next); then compound 2; then compound 3.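

In this assay, the step of a number 78.8 percentage points lower from compound 3 to compound 4 (beyond the scatter) shows that a third aromatic ring on the carbonyl, this time ((thiophen-2-yl)carbonyl)oxy, again brings a large fall when it replaces hydrogen on this saturated ring carbon, so compounds 1, 2 and 4 all lie far under compound 3. The ring on the carbonyl also matters unevenly: the step of a number 0.4 percentage points higher from compound 1 to compound 4 (within the scatter) separates thiophen-2-yl from pyridin-4-yl by no more than the scatter, whereas the step of a number 16.2 percentage points lower from compound 2 to compound 4 (beyond the scatter) leaves the 4-methylphenyl compound modestly apart from the thiophene compound. No measurement shown here offers an explanation for any of these differences.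

The compounds shown leave open whether a plain hydroxyl group, an amine or an amide link on this same ring carbon would stay close to compound 3 or fall as far as compound 4. They also leave open whether a short alkyl chain in place of the aromatic ring on the carbonyl would change the number, and whether other substituents on the phenyl ring would move it further from that of compound 4.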